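Replacing cyclopropyl with acetyl on an amine nitrogen

The source may report more compounds than this note shows. Statements on the series, on what has been measured and on what is new or still open speak of the compounds shown alone.

In an ADME assay on HEp-2 cells (Homo sapiens) for cytotoxicity (a higher number here means that more compound is tolerated, a lower number that less compound is tolerated), compound 1 `CC(C)CCn1c(Cn2c(=O)n(C(C)C)c3ccccc32)nc2cc(CN)ccc21` gives 3920 nM as its result. Compound 2 `CC(C)CCn1c(Cn2c(=O)n(C(C)C)c3ccccc32)nc2cc(CNC3CC3)ccc21` gives 17200 nM and holds the higher of the two numbers, so more of it is tolerated. The two compounds share a core and differ in one place, with cyclopropyl in place of hydrogen on an amine nitrogen. The measured step is a 4.4-fold higher number from compound 1 to compound 2 (0.64 log units; beyond the scatter) and lies beyond the scatter, although it is modest.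

Compound 3 `CC(=O)NCc1ccc2c(c1)nc(Cn1c(=O)n(C(C)C)c3ccccc31)n2CCC(C)C` changes that same place, with acetyl in place of cyclopropyl on the amine nitrogen, a difference counted as acetyl in place of cyclopropyl on an amine nitrogen in full. Within the data shown here, only the step from hydrogen to cyclopropyl bears on this change, and no measured compound carries acetyl, so the evidence is thin. From the compounds shown here alone, its direction stays open, and nothing measured points clearly either way. The expected change is a 1.3-fold higher number from compound 2 to compound 3 (0.11 log units; within the scatter) at the middle of the estimate, with no shift beyond the scatter firmly anticipated. In this assay compound 3 is estimated at 22000 nM with 7000 nM to 70000 nM as its expected range.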

Compound 3, half-maximal cytotoxic concentration: 178000 nM
Compound 3: the middle estimate sits 8.1-fold (0.91 log units) below what was measured; the measured number lies above the stated range.
By their numbers in this assay, from the lowest: compound 1; then compound 2; then compound 3.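

In this assay the group on this amine nitrogen turns out to move the number much further than the first pair suggested: acetyl gives a 10-fold higher number from compound 2 to compound 3 (1.01 log units; beyond the scatter) when it takes the place of cyclopropyl, and a 45-fold higher number from compound 1 to compound 3 (1.66 log units; beyond the scatter) when it takes the place of hydrogen, both of them large steps. Each of these exceeds the modest 4.4-fold higher number from compound 1 to compound 2 (0.64 log units; beyond the scatter) and, with cyclopropyl and acetyl at 3 heavy atoms each, the count of heavy atoms alone does not set the number here, while acetyl differs in carrying a hydrogen-bond acceptor and no ring. Nothing available explains why the acetamidomethyl compound tolerates so much more.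

The compounds shown leave open whether the high number belongs to acetyl in particular or to any carbonyl on this nitrogen, a question that a propanoyl or benzoyl group could help settle. A plain ethyl group on the nitrogen would show whether losing the three-membered ring counts by itself, and all of this rests on a single position of one shared core.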